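Trimming an alkylamino chain: expected cytotoxicity on Vero cells

The compounds below may be only part of what the source reports. "The series", "measured", "known", "first", "only" and "open" are said of these compounds alone.

Measured compounds:
compound 1 `CCCCCCCNc1cnc(C(=O)NCc2ccccc2)cn1` — >= 100000 nM
compound 2 `CCCCCNc1nccnc1C(=O)NCc1ccccc1` — > 100000 nM
compound 3 `CCCCNc1nccnc1C(=O)NCc1ccccc1` — > 100000 nM

Compound 1 stands only at a limit in an ADME assay on Vero cells (Chlorocebus sabaeus) for cytotoxicity, read by microscopy, with a stated time of 6 days; a higher number here means that more compound is tolerated, a lower number that less compound is tolerated: its value of >= 100000 nM is a limit of the assay and not a number. Compound 2 likewise sits at a limit, > 100000 nM. Compound 3 also sits at a limit, > 100000 nM. For the measured compounds named here, the one measured step, a step that the two limits leave unreadable from compound 2 to compound 3, is a chain shortening of the same kind but cannot be read, because both compounds sit at the limit of > 100000 nM in this assay, at which 2 of the 3 values shown sit.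

Compound 4 `CCCCCNc1cnc(C(=O)NCc2ccccc2)cn1` differs from compound 1 by hydrogen in place of ethyl on a saturated chain carbon, five bonds along the chain from a nitrogen on an aromatic ring, a change of the same kind as the step between compound 2 and compound 3. Going by the values given here, since compound 1 rests at the limit of >= 100000 nM in this assay, at which 1 of the 3 values shown sits, and the only comparable step is unreadable, no direction beyond the scatter can be expected. Compound 4 is therefore expected to give 100000 nM, within 50000 nM to 200000 nM. The expected step of a number no higher from compound 1 to compound 4 (the limit leaves the size open) is thus estimated to be none beyond the scatter, most likely ending again at a limit.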

Compound 4, minimum cytotoxic concentration: > 100000 nM
Compound 4 was reported as a limit; the forecaster's own chance of this, stated with the estimate: 85%; the middle value lies on the limit itself.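

No new step can be read from compound 4: compound 1 and compound 4 both stand at limits in this assay, and neither value is a number. The compounds shown leave open whether shortening the chain changes the tolerated concentration at all: none of them gives a number.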